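This account rests on a few compounds, and the source may have more. Where it says the series, first, only, none or still open, it means among the compounds named here.

Compound 1 `CCCCCCC(CCCCCC)c1cccc(N2CCNCC2)n1` in a functional assay on the whole organism with Mus musculus as the target, in the maximal electroshock model, with a stated time of 120 min (a higher number here means that more compound is needed for the effect, a lower number that less compound is needed), gives > 300 mg/kg, which is a limit of the assay and not a number.
Compound 2 `c1cc(CC2CCCCC2)nc(N2CCNCC2)c1` in this assay gives 100 mg/kg.
Compound 3 `CCCCCc1cccc(N2CCNCC2)n1` in this assay gives 10 mg/kg.

Compound 1 thus stands only at a limit of > 300 mg/kg in this assay, at which 1 of the 3 values shown sits, and has no number of its own. The unmeasured compound 4 `CCCCCCCc1cccc(N2CCNCC2)n1` differs from it in one place: hydrogen in place of hexyl on a saturated chain carbon bound to an aromatic carbon and a saturated chain carbon. Going by the values given here, the one measured step that bears on this change is a 10-fold lower number from compound 2 to compound 3 (1.00 log units; beyond the scatter), where a smaller saturated group went with a lower number. Compound 4 carries a straight chain like that of compound 3, so a number well below the limit seen for compound 1 is expected. For compound 4 the expected step is an at least 10-fold lower number from compound 1 to compound 4 (1.00 log units; beyond the scatter). The estimate for compound 4 is 30 mg/kg, with a range of 10 mg/kg to 100 mg/kg.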

Compound 4, minimum effective dose: 10 mg/kg
Estimate against measurement, compound 4: 3.0-fold (0.48 log units) above, and the stated range covers the measured number.
By their numbers in this assay, from the lowest: compounds 3 and 4 (each within the scatter of the next); then compound 2. At a limit, above all of these: compound 1.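

In this assay, hydrogen in place of hexyl on the saturated chain carbon bound to an aromatic carbon gives an at least 30-fold lower number from compound 1 to compound 4 (1.47 log units; beyond the scatter), a step that starts from a limit of the assay and not from a number. The straight chain of compound 3 can carry ethyl at its end with no change at the digits printed from compound 3 to compound 4 (within the scatter). Hexyl in place of cyclohexyl gives a 10-fold lower number from compound 2 to compound 4 (1.00 log units; beyond the scatter), matching the earlier step from compound 2 to compound 3.

The compounds shown leave open how a methyl branch on that same carbon would read, and whether a decyl chain or a terminal hydroxyl would hold the number of compound 4.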